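Fluoro step on the aryl group in a short indole-type series

A few compounds are considered here, and "the series" means these few. Any claim that something is new, unique, unknown or untested is made for them only; others in the source may bear on it.

Measured so far in a functional assay on HeLa cells (Homo sapiens) for cytotoxicity, read by MTT assay, with a stated time of 2 days, tested at 1 uM; on this read-out higher numbers stand for a weaker effect at the one concentration tested and lower numbers for a stronger effect:
compound 1, `CC(=O)c1cc(-c2ccccc2)cc2cc(-c3ccc(F)cc3)[nH]c12`, 85.1%
compound 2, `CC(=O)c1cc(-c2ccc(F)cc2)cc2cc(-c3ccc(F)cc3)[nH]c12`, 71.6%
compound 3, `CC(=O)c1cc(/C=C/c2ccccc2)cc2cc(-c3ccccc3)[nH]c12`, 79.8%

Compound 1 and compound 2 differ by one change, (fluoro in place of hydrogen on an aromatic carbon), and this change made the step of a number 13.5 percentage points lower from compound 1 to compound 2 (beyond the scatter). Compound 3 carries a different core; how the core of compound 3 differs from that of compound 1 is not broken down here. Its value sits between the two, within the scatter of both compound 1 and compound 2.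

Compound 4, `CC(=O)c1cc(/C=C/c2ccccc2)cc2cc(-c3ccc(F)cc3)[nH]c12`, remains to be measured. It differs from compound 3 by fluoro in place of hydrogen on an aromatic carbon, which is the same change as that from compound 1 to compound 2, made at the same kind of place on the other core. Among the compounds with values here, only one earlier instance of this change is known, so the expectation rests on that single step. The step from compound 3 to compound 4 is expected to be a number 11.8 percentage points lower from compound 3 to compound 4 (beyond the scatter) in this assay, because the same change gave a number 13.5 percentage points lower from compound 1 to compound 2 (beyond the scatter). For compound 4 the estimated value in this assay is 68%, expected to fall between 55% and 82%.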

Compound 4, a percentage reported as activity, at one concentration (the size of the read-out at that concentration, not a potency): 60.5%
Compound 4: the middle estimate sits 7.5 percentage points above what was measured, within the range that was stated.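

In this assay, phenyl to 4-fluorophenyl on the second core gives a number 19.3 percentage points lower from compound 3 to compound 4 (beyond the scatter) and matches the earlier instance, so the change carries over between these two cores: the same change on two cores in this assay, a number 13.5 percentage points lower (beyond the scatter) from compound 1 to compound 2 and a number 19.3 percentage points lower (beyond the scatter) from compound 3 to compound 4, 5.8 percentage points apart, within the scatter of two such steps. With the 4-fluorophenyl group held on the other side of the molecule, 2-phenylethenyl gives a number 11.1 percentage points lower from compound 2 to compound 4 (beyond the scatter) and a number 24.6 percentage points lower from compound 1 to compound 4 (beyond the scatter) in the two comparisons, so the core also bears on the read-out. Two pairs at one concentration show neither a change in potency nor transfer to any further core.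

Still open, as far as these compounds go, is whether a chloro, methoxy or nitrile group at the same place on the ring would give a similar step. Also open, from the compounds shown here alone, is how an amine or a carboxylic acid there would read.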